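Methylsulfonyl Gives Way to a Five-Membered Ring

A few compounds are considered here, and "the series" means these few. Any claim that something is new, unique, unknown or untested is made for them only; others in the source may bear on it.

Compound 1, `CCOCc1c(C)nc2c(OCc3ccccc3)cccn12`: 84%
Compound 2, `Cc1nc2c(OCc3ccccc3)cccn2c1CS(C)(=O)=O`: 61%

In a functional assay on the whole organism with Rattus norvegicus as the target, with a stated time of 4 h, at a dose of 40 mg/kg by the intraperitoneal route (on this read-out higher numbers stand for more inhibition at the one dose given (going by the name of the read-out) and lower numbers for less inhibition), compound 1 gives 84%, while compound 2 gives 61%. Among the compounds with values here, compound 2 therefore stands lowest of the two numbers, and the only measured step is a number 23 percentage points lower from compound 1 to compound 2 (beyond the scatter), a change at the same saturated chain carbon bound to an aromatic carbon.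

Compound 3, `Cc1nc2c(OCc3ccccc3)cccn2c1CC1=NCCN1`, is not yet measured. It differs from compound 2 in one place: a group of 5 heavy atoms (3 carbon, 2 nitrogen; one five-membered non-aromatic ring with 2 hetero atoms) in place of a group of 4 heavy atoms (1 carbon, 2 oxygen, 1 sulfur; no ring), on a saturated chain carbon bound to an aromatic carbon. Within the data shown here, the one measured step bears on it only loosely, since it exchanged ethoxy for methylsulfonyl rather than methylsulfonyl for the ring now entering; its size was modest. Among the measured compounds shown here, no step with the entering group exists. Compound 3 is therefore expected to land near compound 2, with a number 4 percentage points higher from compound 2 to compound 3 (within the scatter), and its estimated value is 65%, between 40% and 88%.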

Compound 3, a percentage reported as inhibition, in the whole organism at one dose (the size of the read-out at that dose, not a potency): 69%
Compound 3: the middle estimate sits 4 percentage points below what was measured; the measured number falls inside the stated range.
By their numbers in this assay, from the lowest: compounds 2 and 3 (each within the scatter of the next); then compound 1.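

In this assay the exchange of methylsulfonyl for the five-membered non-aromatic ring with 2 hetero atoms, on a saturated chain carbon bound to an aromatic carbon, gives a number 8 percentage points higher from compound 2 to compound 3 (within the scatter) and so does not separate these two groups at this dose. Set against ethoxy, the same ring gives a number 15 percentage points lower from compound 1 to compound 3 (beyond the scatter) and so, like methylsulfonyl, stays short of the ethoxy compound, even though it brings a ring and 1 hydrogen-bond donor to this position. No measurement is available that would explain either step.

The compounds shown leave open whether an amine or a longer ether chain such as propoxy on this carbon would match or pass ethoxy. They also leave open whether the picture seen at this single dose and time would hold at other doses.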